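Will Compound 4 Keep the Low Number of Compound 3?

The source may hold more compounds than are shown below. What is called first, only, known or untested is meant among the compounds shown, and "the series" means these compounds.

In a functional assay on SW-620 cells (Homo sapiens) for cytotoxicity, read by MTT assay, with stated times of 4 h and 72 h, tested at 2 uM (on this read-out lower numbers stand for stronger inhibition and higher numbers for weaker inhibition), compound 1 (`Cc1ccc(/C=C/C(=O)c2ccc(Nc3cc(C)nc4nc(SCc5nc6ccccc6[nH]5)nn34)cc2)cc1`) gives 1520 nM and compound 2 (`Cc1cc(Nc2ccc(C(=O)/C=C/c3ccc(C(F)(F)F)cc3)cc2)n2nc(SCc3nc4ccccc4[nH]3)nc2n1`) gives 1850 nM while compound 3 (`Cc1cc(Nc2ccc(C(=O)/C=C/c3ccc4ccccc4c3)cc2)n2nc(SCc3nc4ccccc4[nH]3)nc2n1`) gives 5 nM as the lowest of the three numbers. Compound 4 (`Cc1cc(Nc2ccc(C(=O)/C=C/c3ccc(-n4cccn4)cc3)cc2)n2nc(SCc3nc4ccccc4[nH]3)nc2n1`) keeps the shared core but carries 4-(1H-pyrazol-1-yl)phenyl in place of naphthalen-2-yl on the double-bonded chain carbon (4-(1H-pyrazol-1-yl)phenyl in place of naphthalen-2-yl on a double-bonded chain carbon bound to a double-bonded chain carbon). Two measured steps changed that same place, and both are large: a 300-fold lower number from compound 1 to compound 3 (2.48 log units; beyond the scatter) and a 370-fold lower number from compound 2 to compound 3 (2.57 log units; beyond the scatter) in the same test. Changing the group on the phenyl ring mattered far less, with a 1.2-fold higher number from compound 1 to compound 2 (0.09 log units; within the scatter) as the result. Compound 4 also has a phenyl ring bearing a group, so it may resemble compound 1 at 1520 nM more than compound 3, although its second ring could preserve part of the low number. The expected change is a 60-fold higher number from compound 3 to compound 4 (1.78 log units; beyond the scatter) as a large step toward weaker inhibition in this assay overall. For compound 4 the estimated value is 300 nM with an expected range from 15 nM to 2500 nM here.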

Compound 4, half-maximal inhibitory concentration: 340 nM
Compound 4: middle estimate off by 1.1-fold (0.05 log units), on the low side; low and high end bracket the measured number.
By their numbers in this assay, from the lowest: compound 3; then compound 4; then compounds 1 and 2 (each within the scatter of the next).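

In this assay, the step from naphthalen-2-yl to 4-(1H-pyrazol-1-yl)phenyl is a 68-fold higher number from compound 3 to compound 4 (1.83 log units; beyond the scatter) and is large, so carrying two aromatic rings is not enough on its own to keep the very low number of compound 3. Yet the 1H-pyrazol-1-yl group gives a 4.5-fold lower number from compound 1 to compound 4 (0.65 log units; beyond the scatter) and also a 5.4-fold lower number from compound 2 to compound 4 (0.74 log units; beyond the scatter), which shows that the group on this phenyl ring can shift the number beyond the scatter, something the swap between methyl and trifluoromethyl did not show. No measurement shown here explains either change.

From the compounds shown here alone, it remains open whether the nitrogens of the 1H-pyrazol-1-yl group play any part in this gain. A plain phenyl group on that same aromatic carbon, or an amine such as morpholine there, would help to separate the effect of the ring from that of its nitrogens.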